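Working notes: from compound 3 to compound 4

The source may hold more compounds than are shown below. What is called first, only, known or untested is meant among the compounds shown, and "the series" means these compounds.

Going by the values given here, the series shares one core carrying the chlorobenzyloxy arm; the three measured members differ only at one position. In an assay on isolated protein (strain Sprague-Dawley) for inhibition of Amine oxidase [flavin-containing] A (Rattus norvegicus), read by spectrophotometry, with a stated time of 5 min, tested at 10 uM (a higher number here means more inhibition at the concentration tested (going by the name of the read-out), a lower number less inhibition), compound 1 `COCOc1cc(=O)oc2cc(OCc3cccc(Cl)c3)ccc12` gives 23%, compound 2 `CNC(=O)COc1cc(=O)oc2cc(OCc3cccc(Cl)c3)ccc12` gives 11%, and compound 3 `O=c1cc(Oc2ccccc2)c2ccc(OCc3cccc(Cl)c3)cc2o1` gives 0%. Compound 3 stands lowest of the three: the step of a number 23 percentage points lower from compound 1 to compound 3 (beyond the scatter) and the step of a number 11 percentage points lower from compound 2 to compound 3 (beyond the scatter) both run downward and both lie beyond the scatter, as does a number 12 percentage points lower from compound 1 to compound 2 (beyond the scatter).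

Compound 4 `O=c1cc(CCl)c2ccc(OCc3cccc(Cl)c3)cc2o1` is not yet measured. It differs from compound 3 in one place: chloromethyl in place of phenoxy on an aromatic carbon. Among the compounds with values here, no measured step covers this exact change, since every measured step keeps an oxygen at that position and only varies what hangs on it. Within the data shown here, the two steps that touch the same place, a number 23 percentage points lower from compound 1 to compound 3 (beyond the scatter) and a number 11 percentage points lower from compound 2 to compound 3 (beyond the scatter), are the only guide: in both, the larger phenyl group sits at the bottom of the series. Only a modest upward step, if any, is therefore expected for compound 4 in this assay, a number 12 percentage points higher from compound 3 to compound 4 (beyond the scatter), with the wide uncertainty that an untested kind of change brings. Compound 4 is estimated at 12%, with a range of 0% to 35%.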

Compound 4, a percentage reported as inhibition, at one concentration (the size of the read-out at that concentration, not a potency): 21%
Compound 4: middle estimate off by 9 percentage points, on the low side; low and high end bracket the measured number.
By their numbers in this assay, from the lowest: compound 3; then compounds 2, 4 and 1 (each within the scatter of the next, the first and the last beyond it).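

The step of a number 21 percentage points higher from compound 3 to compound 4 (beyond the scatter) in this assay shows that this aromatic carbon, opposite the ring oxygen, does not need an oxygen-linked substituent to give a reading: chloromethyl, with no ring, replaces phenoxy and the number rises beyond the scatter. The steps of a number 10 percentage points higher from compound 2 to compound 4 (within the scatter) and a number 2 percentage points lower from compound 1 to compound 4 (within the scatter) put chloromethyl on a level with (methylcarbamoyl)methoxy and methoxymethoxy, so among these four compounds the linking oxygen alone does not separate the groups, and phenoxy, the only one carrying a ring, is the group that stands apart. No measured evidence accounts for this difference between phenoxy and chloromethyl.

The compounds shown leave open whether the chlorine of chloromethyl matters, which a plain methyl or a hydroxymethyl group at the same carbon would test. They also leave open whether a phenyl ring joined directly to this carbon, a benzyl group, an amine or a carboxylic acid would follow phenoxy or chloromethyl, and whether any group here lifts the inhibition clearly above the level of compound 1 and compound 4.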